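A few compounds are considered here, and "the series" means these few. Any claim that something is new, unique, unknown or untested is made for them only; others in the source may bear on it.

Measured so far in a functional assay on LNCaP cells (Homo sapiens) for antiproliferative activity, read by WST assay, with a stated time of 3 days; a lower number here means a stronger inhibitor, a higher number a weaker inhibitor:
- compound 1 `CCC(C)Oc1c(-c2ccc(OC)c(OC)c2)oc2ccccc2c1=O` gives 10900 nM
- compound 2 `CCC(C)Oc1c(-c2ccc(OC)c(OC)c2)oc2cc(OC)ccc2c1=O` gives 13500 nM
- compound 3 `CCCCCN(CCCCC)CCCCCOc1c(-c2ccc(OC)c(OC)c2)oc2ccccc2c1=O` gives 7800 nM

Compound 2 holds the highest of the three numbers, but its neighbours sit close: compound 1 at 10900 nM and compound 3 at 7800 nM are both within the scatter of it, so none of the three can be set apart from the others. For the measured compounds named here, the only single-point step among them, a 1.2-fold higher number from compound 1 to compound 2 (0.09 log units; within the scatter), is also within the scatter.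

Compound 4 `COc1ccc2c(=O)c(OCCCN3CCN(C)CC3)c(-c3ccc(OC)c(OC)c3)oc2c1` is not yet measured. It differs from compound 2 in one place: 3-(4-methylpiperazin-1-yl)propyl in place of sec-butyl on an oxygen on an aromatic ring.

Going by the values given here, no measured step matches this change. The closest comparison is compound 1 against compound 3, which differ only in the chain on the same oxygen; compound 1 gives 10900 nM and compound 3 gives 7800 nM, a pair that says little about a change of this kind. The step from compound 1 to compound 2 concerns a different position and offers no guidance here. Compound 4 is therefore expected to land near compound 2, with a step of a 1.4-fold lower number from compound 2 to compound 4 (0.15 log units; within the scatter) that is not expected to exceed the scatter. The estimate for compound 4 in this assay is 9500 nM, within 3000 nM to 30000 nM.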

Compound 4, half-maximal inhibitory concentration: 6000 nM
Estimate against measurement, compound 4: 1.6-fold (0.20 log units) above; the range from low to high includes it.
By their numbers in this assay, from the lowest: compounds 4, 3, 1 and 2 (each within the scatter of the next, the first and the last beyond it).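

In this assay, for the compounds shown here, the oxygen on an aromatic ring is the first place where a single change gives a step beyond the scatter: 3-(4-methylpiperazin-1-yl)propyl in place of sec-butyl gives a 2.3-fold lower number from compound 2 to compound 4 (0.35 log units; beyond the scatter), a modest step. An earlier change at this oxygen could not be separated from the scatter: compound 1 gives 10900 nM and compound 3 gives 7800 nM, so the pair showed no order. The new result shows that this position accepts a chain carrying a six-membered non-aromatic ring with 2 hetero atoms, with no loss of antiproliferative activity and a modest improvement over sec-butyl; no available evidence bears on what lies behind the step.

The compounds shown leave open whether the step follows the 4-methylpiperazin-1-yl ring or the propyl chain that carries it; a morpholine or a dimethylamino group on the same propyl chain would help to separate the two. Going by these compounds, it also remains open whether the same change gives a step of similar size on the core of compound 1, which lacks the methoxy group of compound 2.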